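Trimming a fluorinated ether chain on the shared core

The source may report more compounds than this note shows. Statements on the series, on what has been measured and on what is new or still open speak of the compounds shown alone.

Measured compounds:
compound 1 `Cc1cc(CCC(=O)O)ccc1-c1noc(-c2ccc(OC(C)C)c(C#N)c2)n1`: 6.5 nM
compound 2 `Cc1cc(CCC(=O)O)ccc1-c1noc(-c2ccc(OC(C(F)(F)F)C(F)(F)F)c(C#N)c2)n1`: 0.7 nM

In a functional assay on CHO cells for agonist activity at sphingosine 1-phosphate receptor 5 (Homo sapiens), read by GTPgammaS binding (on this read-out lower numbers stand for an effect already at smaller amounts and higher numbers for an effect only at larger amounts of compound), compound 2 gives the lowest of the two numbers; the nearest is compound 1, reached by a 9.3-fold lower number from compound 1 to compound 2 (0.97 log units; beyond the scatter). Compound 3 `Cc1cc(CCC(=O)O)ccc1-c1noc(-c2ccc(OCC(F)(F)F)c(C#N)c2)n1` differs from compound 2 by hydrogen in place of trifluoromethyl on a saturated chain carbon bound to an oxygen on an aromatic ring and a saturated chain carbon, which, cut one bond further out, reads 2,2,2-trifluoro-1-(trifluoromethyl)ethoxy to 2,2,2-trifluoroethoxy. Among the compounds with values here, only one measured step touches this part of the core: the change a 9.3-fold lower number from compound 1 to compound 2 (0.97 log units; beyond the scatter), where more fluorine on the ether chain went with a lower number. Compound 3 gives back part of that fluorinated group, so a step toward a higher number is expected in this assay, smaller than the measured one. Compound 3 is therefore estimated at 2.5 nM, within 0.8 nM to 7 nM, meaning an expected step of a 3.6-fold higher number from compound 2 to compound 3 (0.55 log units; beyond the scatter).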

Compound 3, half-maximal effective concentration: 44 nM
Compound 3: middle estimate off by 18-fold (1.25 log units), on the low side; the measured number lies above the stated range.
By their numbers in this assay, from the lowest: compound 2; then compound 1; then compound 3.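

In this assay taking one trifluoromethyl off the ether chain gives a 63-fold higher number from compound 2 to compound 3 (1.80 log units; beyond the scatter) and so undoes more than the whole gain of the earlier step. Putting 2,2,2-trifluoroethyl in place of isopropyl gives a 6.8-fold higher number from compound 1 to compound 3 (0.83 log units; beyond the scatter) even though fluorine enters, so fluorine count alone does not order these compounds: compound 1 carries none and still gives a lower number than compound 3. Both branched groups, isopropyl and 2,2,2-trifluoro-1-(trifluoromethyl)ethyl, give lower numbers than the unbranched 2,2,2-trifluoroethyl, though three compounds are too few to call this a rule.

Nothing measured here explains this order. As far as these compounds go, what a plain ethyl or a 2,2-difluoroethyl chain on the oxygen would give on the shared core stays open, and either could help separate branching from fluorine.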